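The source may report more compounds than this note shows. Statements on the series, on what has been measured and on what is new or still open speak of the compounds shown alone.

Measured compounds:
compound 1 `O=C(CCc1nc2ccccc2c(=O)[nH]1)N/N=C/c1ccc(O)c(O)c1` — 113000000 nM
compound 2 `COc1cc(/C=N/NC(=O)CCc2nc3ccccc3c(=O)[nH]2)cc(OC)c1O` — 126000000 nM

In a physicochemical assay, read by spectrophotometry, with a stated time of 30 min (a lower number here means a stronger inhibitor, a higher number a weaker inhibitor), compound 1 gives 113000000 nM; in this assay compound 2 gives 126000000 nM. Compound 2 has the highest number of the two, its nearest neighbour being compound 1, and the gap between them lies within the scatter, so no order between the two can be read from these numbers. Both are weak.

Compound 3 `COc1cc(/C=N/NC(=O)CCc2nc3ccccc3c(=O)[nH]2)ccc1O` is yet to be measured in this assay. It differs from compound 2 by hydrogen in place of methoxy on an aromatic carbon. Among the compounds with values here, no step between measured compounds covers this change. Compound 1 and compound 2 sit within the scatter of each other although their substitution differs at more than one place, so for compound 3 no step beyond the scatter is expected in either direction. The estimate for compound 3 in this assay is 120000000 nM, with a range from 50000000 nM to 300000000 nM. The step of a 1.1-fold lower number from compound 2 to compound 3 (0.02 log units; within the scatter) implied by this estimate is expected to stay within the scatter.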

Compound 3, half-maximal inhibitory concentration: 204000000 nM
For compound 3 the middle estimate is 1.7-fold (0.23 log units) below the measured one, and the stated range covers the measured number.
By their numbers in this assay, from the lowest: compounds 1, 2 and 3 (each within the scatter of the next).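

In this assay, hydrogen in place of methoxy on the aromatic carbon ortho to a hydroxy group gives a 1.6-fold higher number from compound 2 to compound 3 (0.21 log units; within the scatter), so the first step read directly at this position shows no change that can be separated from the scatter. Methyl in place of hydrogen on an oxygen on the aromatic ring gives a 1.8-fold higher number from compound 1 to compound 3 (0.26 log units; within the scatter), so this second single change also stays within the scatter, and neither step gives an order among the compounds involved. No supporting evidence bears on these two results.

Going by these compounds, whether any substituent at this position can move the number beyond the scatter remains open, since both readable changes leave the compounds weak. On these data alone, the effect of an amine or chlorine on this aromatic carbon, or of a longer chain on the oxygen, also remains open.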